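The compounds below may be only part of what the source reports. "The series", "measured", "known", "first", "only" and "open" are said of these compounds alone.

Measured in a functional assay on A549 cells (Homo sapiens) for antiproliferative activity, read by MTT assay, with a stated time of 48 h; a higher number here means a weaker inhibitor, a lower number a stronger inhibitor:
- Compound 1 `COC/C1=C/C[C@](C)(CCC=C(C)C)/C=C/[C@@H](OC(=O)C=C(C)C)[C@](C)(O)/C=C/C1=O`: 3950 nM
- Compound 2 `CSC(=S)OC/C1=C/C[C@](C)(CCC=C(C)C)/C=C/[C@@H](OC(=O)C=C(C)C)[C@](C)(O)/C=C/C1=O`: 380 nM
- Compound 3 `CO/N=C/C1=C/C[C@](C)(CCC=C(C)C)/C=C/[C@@H](OC(=O)C=C(C)C)[C@](C)(O)/C=C/C1=O`: 3470 nM

Compound 3 gives 3470 nM, a number within the scatter of that of compound 1 and well above that of compound 2. Compound 4 `CCN(CC)C(=O)/C1=C/C[C@](C)(CCC=C(C)C)/C=C/[C@@H](OC(=O)C=C(C)C)[C@](C)(O)/C=C/C1=O` differs from compound 3 on a double-bonded ring carbon: a group of 7 heavy atoms (5 carbon, 1 nitrogen, 1 oxygen; no ring) in place of a group of 4 heavy atoms (2 carbon, 1 nitrogen, 1 oxygen; no ring), on a double-bonded ring carbon. The nearest evidence is a 1.1-fold lower number from compound 1 to compound 3 (0.06 log units; within the scatter), which stayed within the scatter. Yet a 10-fold lower number from compound 1 to compound 2 (1.02 log units; beyond the scatter) and a 9.1-fold higher number from compound 2 to compound 3 (0.96 log units; beyond the scatter) both went beyond it, so a larger move cannot be ruled out. Going by the values given here, no measured compound carries diethylcarbamoyl. In this assay, no step beyond the scatter is expected, and the estimated change is a 1.2-fold lower number from compound 3 to compound 4 (0.06 log units; within the scatter). For compound 4 the estimated value is 3000 nM, with an expected range of 900 nM to 10000 nM.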

Compound 4, half-maximal inhibitory concentration: 11300 nM
Compound 4: the middle estimate sits 3.8-fold (0.58 log units) below what was measured; measured number outside the range, above it.
By their numbers in this assay, from the lowest: compound 2; then compounds 3 and 1 (each within the scatter of the next); then compound 4.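

In this assay, the change at this double-bonded ring carbon now moves the number upward, with a 3.3-fold higher number from compound 3 to compound 4 (0.51 log units; beyond the scatter) and a 2.9-fold higher number from compound 1 to compound 4 (0.46 log units; beyond the scatter) both beyond the scatter. The position therefore does not accept every group without loss, and a 30-fold higher number from compound 2 to compound 4 (1.47 log units; beyond the scatter) makes compound 4 the weakest of the four compounds. Nothing measured here accounts for this shift. The compounds shown leave open whether the loss follows the carbonyl-linked nitrogen itself or the diethyl chains, which a dimethylcarbamoyl group or a carboxylic acid at this carbon could separate.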